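Swapping an Ester for a Methyl Ketone on the Core

A few compounds are considered here, and "the series" means these few. Any claim that something is new, unique, unknown or untested is made for them only; others in the source may bear on it.

Measured so far in a functional assay on 786-0 cells (Homo sapiens) for inhibition, read by sulforhodamine B assay, with a stated time of 48 h; on this read-out higher numbers stand for weaker inhibition of growth and lower numbers for stronger inhibition of growth:
Compound 1 `C=C(C)[C@@H]1CC=C(Cn2cc(COc3ccccc3C3NC(=O)NC(C)=C3C(=O)OCC)nn2)CC1` gives > 100000 nM, a limit of the assay.
Compound 2 `C=C(C)[C@@H]1CC=C(Cn2cc(COc3cc(C4NC(=O)NC(C)=C4C(=O)OCC)ccc3OC)nn2)CC1` gives > 100000 nM, also a limit of the assay.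
Compound 3 `C=C(C)[C@@H]1CC=C(Cn2cc(COc3cccc(C4NC(=O)NC(C)=C4C(C)=O)c3)nn2)CC1` gives 44100 nM.

Compound 1 therefore stands at the limit of > 100000 nM in this assay, at which 2 of the 3 values shown sit; no number is known for it. Among the measured compounds shown here, compound 4 `C=C(C)[C@@H]1CC=C(Cn2cc(COc3ccccc3C3NC(=O)NC(C)=C3C(C)=O)nn2)CC1` is the one change not yet measured: methyl in place of ethoxy on a carbonyl carbon, or read one bond further out, ethoxycarbonyl to acetyl. Compound 3, which also carries an acetyl, is the only one of the three with a number rather than a limit. On that basis the step is expected to be an at least 1.4-fold lower number from compound 1 to compound 4 (0.15 log units; that floor lies within the scatter), running towards stronger inhibition, perhaps beyond the scatter but not far. Compound 4 is thus estimated at 70000 nM, within 25000 nM to 200000 nM.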

Compound 4, concentration for total growth inhibition: 80300 nM
Beside the measured number, compound 4's estimate is 1.1-fold (0.06 log units) below it; the range from low to high includes it.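

In this assay, methyl in place of ethoxy on a carbonyl carbon gives an at least 1.2-fold lower number from compound 1 to compound 4 (0.09 log units; that floor lies within the scatter). This turns a limit into a number at this position, though the floor of the step does not clear the usual scatter. Compound 1 holds only a limit, so the true size of the step cannot be read: the limit of > 100000 nM in this assay, at which 2 of the 4 values shown sit.

From the compounds shown here alone, what an amine or a longer chain in place of methyl on this carbonyl carbon would give stays open. Also open, going by these compounds, is whether the same swap would change the reading for compound 2, which keeps the ethoxy.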